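A few compounds are considered here, and "the series" means these few. Any claim that something is new, unique, unknown or untested is made for them only; others in the source may bear on it.

In an ADME assay on BJ cells (Homo sapiens) for cytotoxicity, with a stated time of 72 h (a higher number here means that more compound is needed for the effect, a lower number that less compound is needed), two compounds have been measured so far, and neither gives a number. Compound 1 (`C=C[C@@](C)(/C=C/c1ccc(Nc2ccc(F)cc2)cc1)CCC=C(C)C`) reads > 36600 nM, which is a limit and not a measured value. Compound 2 (`C=C[C@@](C)(/C=C/c1ccc(-c2ccccc2)cc1)CCC=C(C)C`) reads > 36600 nM, which is likewise a limit. Both therefore stand at the limit of > 36600 nM in this assay, at which 2 of the 2 values shown sit. Within the data shown here, the only measured step is a step that the two limits leave unreadable from compound 1 to compound 2, so it offers no size to carry forward. Compound 3 (`C=C[C@@](C)(/C=C/c1ccc(-c2ccc(Cl)c(Cl)c2)cc1)CCC=C(C)C`) differs from compound 2 by one change: 3,4-dichlorophenyl in place of phenyl on an aromatic carbon. The 3,4-dichlorophenyl takes the place of phenyl, para to a large group. The expectation for this assay rests only on compound 2 and its limit of > 36600 nM, and no clear direction can be drawn from it. The estimated step is a step that the limit leaves unreadable from compound 2 to compound 3, and another limit is the likeliest report. For compound 3 the expected value is 40000 nM, with an estimated range from 15000 nM to 80000 nM.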

Compound 3, half-maximal effective concentration: > 36600 nM
Compound 3: no number, only a limit (the forecaster's own chance of this, stated with the estimate: 75%); the middle value lies beyond the limit too.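

In this assay, compound 3 joins compound 1 and compound 2 in giving only a limit, so no step among the three can be read: the limit of > 36600 nM in this assay, at which 3 of the 3 values shown sit.

The compounds shown leave open how these three compare, and whether any change on the shared core gives a measured number.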